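This account rests on a few compounds, and the source may have more. Where it says the series, first, only, none or still open, it means among the compounds named here.

Three compounds have so far been measured in a functional assay on HCT-116 cells (Homo sapiens) for antiproliferative activity, read by MTT assay; a lower number here means a stronger inhibitor, a higher number a weaker inhibitor:

Compound 1 `CCOC(=O)/C=N/c1cnc(Nc2ccc(S(N)(=O)=O)cc2)nc1NC1CCCC1` gives 9640 nM.
Compound 2 `CCOC(=O)/C=N/c1cnc(Nc2ccc(N3CCN(C)CC3)cc2)nc1NC(C)C` gives 13600 nM.
Compound 3 `CC(C)Nc1nc(Nc2ccc(N3CCN(C)CC3)cc2)ncc1/N=C/c1cccs1` reaches only > 100000 nM, which is a limit of the assay rather than a number.

Compound 2 has the highest of the two numbers read in this assay, with compound 1 a little lower, and the gap between the two is within the scatter. For the measured compounds named here, the one step with two numbers, an at least 7.3-fold higher number from compound 2 to compound 3 (0.86 log units; beyond the scatter), exchanges a group on the carbon that carries a double bond to nitrogen, and compound 3 sits at the limit of > 100000 nM in this assay, at which 1 of the 3 values shown sits.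

Compound 4 `CCOC(=O)/C=N/c1cnc(Nc2ccc(S(N)(=O)=O)cc2)nc1NC(C)C` is the next compound to be measured in this assay. It differs from compound 2 at another place: sulfamoyl in place of 4-methylpiperazin-1-yl on an aromatic carbon. Going by the values given here, no measured step alters this position, so the thiophene step does not bear on it. Compound 1 already carries the sulfamoyl group on the same aromatic carbon, and compound 1 gives 9640 nM, which is within the scatter of compound 2. The change from compound 2 to compound 4 is therefore expected to leave the number about where it is, a step of a 1.4-fold lower number from compound 2 to compound 4 (0.13 log units; within the scatter), none beyond the scatter. Compound 4 is estimated at 10000 nM, between 4000 nM and 30000 nM.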

Compound 4, half-maximal inhibitory concentration: 49100 nM
The estimate for compound 4 lay 4.9-fold (0.69 log units) below the measured number; measured number outside the range, above it.
By their numbers in this assay, from the lowest: compounds 1 and 2 (each within the scatter of the next); then compound 4. At a limit, above all of these: compound 3.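

In this assay, the group on this aromatic carbon turns out to matter, since sulfamoyl in place of 4-methylpiperazin-1-yl, with isopropyl kept on the nitrogen, gives a 3.6-fold higher number from compound 2 to compound 4 (0.56 log units; beyond the scatter) on the same core. The group on the nitrogen matters as well: with sulfamoyl kept in place, isopropyl in place of cyclopentyl gives a 5.1-fold higher number from compound 1 to compound 4 (0.71 log units; beyond the scatter) and is the second single change shown to move the number beyond the scatter, so the closeness of compound 1 and compound 2, which differ in both places, says nothing about either change alone. Nothing measured here gives a reason for either step.

The compounds shown leave open whether cyclopentyl on the nitrogen would also bring a lower number with 4-methylpiperazin-1-yl on the aromatic carbon, which would show whether the two places act independently. They also leave open what a morpholine ring, a plain amine or a carboxylic acid would do on that aromatic carbon, and so whether the piperazine ring itself counts or sulfamoyl is simply a poor choice there.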